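The source may hold more compounds than are shown below. What is called first, only, known or untested is meant among the compounds shown, and "the series" means these compounds.

In a functional assay on MDA-MB-231 cells (Homo sapiens) for antiproliferative activity, read by MTT assay, with a stated time of 72 h (on this read-out higher numbers stand for weaker inhibition and lower numbers for stronger inhibition), the measured compounds stand as follows:
compound 1 `NC1=NC2(CCOCC2)N(OCCCOc2ccccc2Cl)C(N)=N1` gives 1430 nM;
compound 2 `NC1=NC2(CCOCC2)N(OCCCOc2ccccc2Br)C(N)=N1` gives 910 nM;
compound 3 `NC1=NC2(CCSCC2)N(OCCCOc2ccccc2Br)C(N)=N1` gives 10 nM.

Compound 1 differs from compound 2 by chloro in place of bromo on an aromatic carbon. That change produced a 1.6-fold higher number from compound 2 to compound 1 (0.20 log units; within the scatter). Compound 3 carries a core unlike that of compound 2; the difference between the two cores is not broken down here, but the two values lie far apart, with compound 3 at the lowest number of the three. Compound 4 `NC1=NC2(CCSCC2)N(OCCCOc2ccccc2Cl)C(N)=N1` has not yet been measured. For the measured compounds named here, it differs from compound 3 by chloro in place of bromo on an aromatic carbon, the same change as the one from compound 2 to compound 1. Given that the earlier step was a 1.6-fold higher number from compound 2 to compound 1 (0.20 log units; within the scatter), compound 4 is expected to show a 1.6-fold higher number from compound 3 to compound 4 (0.20 log units; within the scatter). Compound 4 is thus estimated at 16 nM, between 5 nM and 50 nM.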

Compound 4, half-maximal inhibitory concentration: 80 nM
Beside the measured number, compound 4's estimate is 5.0-fold (0.70 log units) below it; measured number above the stated range.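

In this assay, replacing bromo with chloro on the core of compound 3 gave an 8.0-fold higher number from compound 3 to compound 4 (0.90 log units; beyond the scatter). Set beside the same replacement on the core of compound 2, the step did not keep its size from one core to the other: the same change on two cores in this assay, a 1.6-fold higher number (0.20 log units; within the scatter) from compound 2 to compound 1 and an 8.0-fold higher number (0.90 log units; beyond the scatter) from compound 3 to compound 4, 5.1-fold (0.71 log units) apart, beyond the scatter of two such steps. This shows that, for these two pairs, the step measured on one core did not predict the step on the other, but two pairs do not show why the steps differ or how the change would behave on any further core.

On these data alone, whether fluoro or methyl on the same aromatic carbon would also give steps that differ between the two cores remains open. So does the size of the bromo-to-chloro step with a longer chain in the linker.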